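This account rests on a few compounds, and the source may have more. Where it says the series, first, only, none or still open, it means among the compounds named here.

So far two compounds have been measured in a functional assay on HeLa cells (Homo sapiens) for antiproliferative activity, read by sulforhodamine B assay; a higher number here means a weaker inhibitor of growth, a lower number a stronger inhibitor of growth. Compound 1 `CCCC[C@@H]1O[C@H](COCc2ccccc2)[C@@H](OCc2ccccc2)[C@H](OCc2ccccc2)[C@H]1O` gives > 50000 nM, which is a limit of the assay and not a number. Compound 2 `CC[C@@H]1O[C@H](COCc2ccccc2)[C@@H](OCc2ccccc2)[C@H](OCc2ccccc2)C1=O` gives > 50000 nM, and this too is a limit. Going by the values given here, compound 2 therefore stands at the same limit as compound 1, so neither offers a true number and no measured step exists to serve as a guide.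

Compound 3 `CC(C)C[C@@H]1O[C@H](COCc2ccccc2)[C@@H](OCc2ccccc2)[C@H](OCc2ccccc2)C1=O` keeps the core of compound 2 and alters one side chain: isopropyl in place of methyl on a saturated chain carbon bound to a saturated ring carbon. Isopropyl sits in place of methyl on a saturated chain carbon bound to a saturated ring carbon, and cut one bond further out, the same difference reads ethyl to isobutyl.

With so little to go on, no change beyond the usual scatter is expected in this assay, and no direction is favoured. This expectation rests on compound 2 at > 50000 nM, which is a limit. The expected step is a number no higher from compound 2 to compound 3 (the limit leaves the size open). Compound 3 is estimated at 50000 nM, with an expected range from 15000 nM to 100000 nM.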

Compound 3, concentration for 50% growth inhibition: > 50000 nM
Compound 3 was reported as a limit (the forecaster's own chance of this, stated with the estimate: 70%); the middle value lies on the limit itself.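

The step from compound 2 to compound 3 cannot be read, since neither compound has a true number, only a limit of the assay: the limit of > 50000 nM in this assay, at which 3 of the 3 values shown sit.

The compounds shown leave open how isopropyl in place of methyl acts on growth inhibition, and which compound around this shared core, if any, would give a true number in this assay.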